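Notes on the step from compound 3 to compound 4

The compounds below may be only part of what the source reports. "The series", "measured", "known", "first", "only" and "open" are said of these compounds alone.

Measured in a functional assay on MDA-MB-436 cells (Homo sapiens) for antiproliferative activity, read by MTT assay, with a stated time of 48 h; on this read-out lower numbers stand for stronger inhibition and higher numbers for weaker inhibition:
- compound 1 `C=CS(=O)(=O)N1CCN(c2ncnc3sc(-c4ccc(OC)cc4)cc23)CC1`: 28400 nM
- compound 2 `C=CS(=O)(=O)N1CCN(c2ncnc3sc(-c4cccc5ncccc45)cc23)CC1`: 25900 nM
- compound 3 `C=CS(=O)(=O)N1CCN(c2ncnc3sc(-c4cn(C)nc4C(F)(F)F)cc23)CC1`: 15100 nM

Compound 3 cannot be separated from the other two measured compounds. The record shows a 1.9-fold lower number from compound 1 to compound 3 (0.27 log units; within the scatter) and a 1.7-fold lower number from compound 2 to compound 3 (0.23 log units; within the scatter), so its place among the values carries no ranking.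

Compound 4 `C=CS(=O)(=O)N1CCN(c2ncnc3sc(-c4cccs4)cc23)CC1` keeps the shared core and has thiophen-2-yl in place of 1-methyl-3-(trifluoromethyl)-1H-pyrazol-4-yl on an aromatic carbon, next to the ring sulfur (thiophen-2-yl in place of 1-methyl-3-(trifluoromethyl)-1H-pyrazol-4-yl on an aromatic carbon).

Among the compounds with values here, the steps that bear on this change are the exchanges at the same place: the two above and a 1.1-fold lower number from compound 1 to compound 2 (0.04 log units; within the scatter). All three stay within the scatter, and none of the three measured compounds goes against that. The group entering here has not been measured in this set, so the comparison is indirect and rests on these three compounds alone.

No step beyond the scatter is therefore expected in this assay, and no firm direction can be drawn. The estimated step is a 1.3-fold higher number from compound 3 to compound 4 (0.12 log units; within the scatter). For compound 4 the expected value is 20000 nM, with an estimated range from 10000 nM to 40000 nM.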

Compound 4, half-maximal inhibitory concentration: 39000 nM
Beside the measured number, compound 4's estimate is 2.0-fold (0.29 log units) below it; the range from low to high includes it.
By their numbers in this assay, from the lowest: compounds 3, 2, 1 and 4 (each within the scatter of the next, the first and the last beyond it).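

In this assay, exchange on an aromatic carbon next to the ring sulfur now gives a step beyond the scatter, though a modest one, with thiophen-2-yl replacing 1-methyl-3-(trifluoromethyl)-1H-pyrazol-4-yl (a 2.6-fold higher number from compound 3 to compound 4 (0.41 log units; beyond the scatter)). This separates only the two ends of the series, as thiophen-2-yl remains within the scatter of quinolin-5-yl (a 1.5-fold higher number from compound 2 to compound 4 (0.18 log units; within the scatter)) and of 4-methoxyphenyl (a 1.4-fold higher number from compound 1 to compound 4 (0.14 log units; within the scatter)), so the position shows limited sensitivity to these four groups, with no ordering among the intermediate pairs. Within the data shown here, no supporting measurement bears on what lies behind the one step beyond the scatter.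

The leaving group and thiophen-2-yl differ in ring hetero atoms, heavy-atom count and substituents at once, so this single exchange cannot show which difference goes with the step; a 1-methyl-1H-pyrazol-4-yl group without the trifluoromethyl would divide that question. Also open is whether an amine or a carboxylic acid on the aromatic group at this position would move the number further in either direction than the four groups shown here.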